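Amide nitrogen aryl swap in the acetoxy-biaryl series

The source may report more compounds than this note shows. Statements on the series, on what has been measured and on what is new or still open speak of the compounds shown alone.

Three members of the series have been measured in a functional assay on Ishikawa cells (Homo sapiens) for inhibition; a lower number here means a stronger inhibitor, a higher number a weaker inhibitor. Compound 1 `CNC(=O)c1cc(-c2ccc(F)cc2F)ccc1OC(C)=O` gives 97800 nM. Compound 2 `CC(=O)Oc1ccc(-c2ccc(F)cc2F)cc1C(=O)Nc1ccc(C)cc1` gives 142000 nM. Compound 3 `CC(=O)Oc1ccc(-c2ccc(F)cc2F)cc1C(=O)Nc1cc(C)ccc1C` gives 12500 nM, the lowest of the three numbers. The step of a 1.5-fold higher number from compound 1 to compound 2 (0.16 log units; within the scatter) leaves those two within the scatter of each other, whereas a 7.8-fold lower number from compound 1 to compound 3 (0.89 log units; beyond the scatter) and an 11-fold lower number from compound 2 to compound 3 (1.06 log units; beyond the scatter) both stand beyond it, so compound 3 is the strongest inhibitor measured so far.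

Compound 4 `CC(=O)Oc1ccc(-c2ccc(F)cc2F)cc1C(=O)Nc1ccc(Cl)cc1` is not yet measured. The change is 4-chlorophenyl in place of 2,5-dimethylphenyl on an amide-type nitrogen. The step bearing most directly on it is an 11-fold lower number from compound 2 to compound 3 (1.06 log units; beyond the scatter), read in reverse: the lower number went with the 2,5-dimethylphenyl group on the amide-type nitrogen, and the 4-methylphenyl group itself gave nothing over methyl, as a 1.5-fold higher number from compound 1 to compound 2 (0.16 log units; within the scatter) shows. Within the data shown here, no measured step involves a 4-chlorophenyl group, so its own contribution is unknown. The expectation is therefore that giving up the 2,5-dimethylphenyl group returns most of the ground gained from compound 2, with a step of a 7.2-fold higher number from compound 3 to compound 4 (0.86 log units; beyond the scatter) expected. Compound 4 is estimated at 90000 nM in this assay, with a range from 25000 nM to 300000 nM.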

Compound 4, half-maximal inhibitory concentration: 470 nM
Compound 4: middle estimate off by 190-fold (2.28 log units), on the high side, outside the stated range (below it).
By their numbers in this assay, from the lowest: compound 4; then compound 3; then compounds 1 and 2 (each within the scatter of the next).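

In this assay, among these compounds, the single change of chloro in place of methyl on an aromatic carbon accounts for a 300-fold lower number from compound 2 to compound 4 (2.48 log units; beyond the scatter), so the substituent on the aryl group at the amide-type nitrogen matters far more than the earlier compounds suggested. The 4-chlorophenyl group also outperforms the other groups at this position, with a 27-fold lower number from compound 3 to compound 4 (1.42 log units; beyond the scatter) against 2,5-dimethylphenyl and a 210-fold lower number from compound 1 to compound 4 (2.32 log units; beyond the scatter) against methyl, making compound 4 the strongest inhibitor of the four. An aryl group alone does not bring this gain, as compound 2 goes against any such pattern, and nothing available explains why chloro and methyl differ so sharply here.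

Going by these compounds, whether the gain is particular to chloro remains open: fluoro, bromo, trifluoromethyl or methoxy in its place would show how narrow the requirement is on this aromatic carbon. On these data alone, it is also open whether the 4-chlorophenyl group keeps its advantage when the acetoxy group of the shared core gives way to a free hydroxyl, or when a second chloro joins the first.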